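Azetidinyl ether linker on the shared core

A few compounds are considered here, and "the series" means these few. Any claim that something is new, unique, unknown or untested is made for them only; others in the source may bear on it.

Measured compounds:
Compound 1 `C=C(C)C(=O)NCCOc1ccc(Oc2c(-c3ccc(F)cc3)sc3cc(O)ccc23)cc1` — in a functional assay on MCF7 cells (Homo sapiens) for antiproliferative activity, read by CCK-8 assay, with a stated time of 48 h (a lower number here means a stronger inhibitor, a higher number a weaker inhibitor), compound 1 reports only a limit, > 25000 nM.
Compound 2 `O=C(/C=C/CN1CC(Oc2ccc(Oc3c(-c4ccc(F)cc4)sc4cc(O)ccc34)cc2)C1)N1CCCC1` — compound 2 gives 8450 nM.
Compound 3 `C/C=C/C(=O)NCCOc1ccc(Oc2c(-c3ccc(F)cc3)sc3cc(O)ccc23)cc1` — compound 3 gives 21700 nM.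

Compound 1 stands at the edge of what the assay resolves: the limit of > 25000 nM in this assay, at which 1 of the 3 values shown sits, so its place relative to the other two is a bound, not a number. For the measured compounds named here, the one single-point step available, an at least 1.1-fold lower number from compound 1 to compound 3 (0.06 log units; that floor lies within the scatter), lies within the scatter and gives no direction to lean on.

The change to compound 4 `CNC(=O)/C=C/CN1CC(Oc2ccc(Oc3c(-c4ccc(F)cc4)sc4cc(O)ccc34)cc2)C1` is 1-(3-(methylcarbamoyl)prop-2-en-1-yl)azetidin-3-yl in place of 2-(((1-methylethenyl)carbonyl)amino)ethyl on an oxygen on an aromatic ring
Going by the values given here, none of the measured steps covers this change, so no measured step bears on it directly. Compound 2, which gives 8450 nM, carries the same azetidin-3-yl oxygen link with another amide at the end of the prop-2-en-1-yl chain, and that is the nearest measured point of reference.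

On that basis compound 4 is expected to land below the limit, with a step of an at least 2.7-fold lower number from compound 1 to compound 4 (0.44 log units; beyond the scatter) that is estimated, not measured. Compound 4 is expected at 9000 nM, within 3500 nM to 25000 nM.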

Compound 4, half-maximal inhibitory concentration: > 25000 nM
Compound 4: no number, only a limit; the forecaster's own chance of this, stated with the estimate: 20%; middle value at least 2.7-fold (0.44 log units) away from the limit.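

In this assay, the azetidin-3-yl oxygen link does not by itself keep a measurable value, and the end group on the carbonyl carbon counts on this link: methylamino in place of pyrrolidin-1-yl gives an at least 2.9-fold higher number from compound 2 to compound 4 (0.47 log units; beyond the scatter). For the compounds shown here, this is the first readable single-point step beyond the scatter, and it points to pyrrolidin-1-yl over methylamino for this one pair only. Against the open-chain amide, an at least 1.1-fold higher number from compound 3 to compound 4 (0.06 log units; that floor lies within the scatter) has a floor within the scatter and gives no direction, the step between compound 1 and compound 4 cannot be read, and the value of compound 4 is only a limit, which it shares with compound 1: the limit of > 25000 nM in this assay, at which 2 of the 4 values shown sit.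

No pair shown changes the azetidin-3-yl link alone while the end amide stays fixed, so the share of the link in the value of compound 2 remains unresolved. Also open, on these data alone, is how the azetidin-3-yl link behaves with other groups on the carbonyl carbon, such as piperidin-1-yl, morpholin-4-yl or dimethylamino, and whether the pyrrolidin-1-yl result extends beyond compound 2.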